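A few compounds are considered here, and "the series" means these few. Any claim that something is new, unique, unknown or untested is made for them only; others in the source may bear on it.

Compound 2, `COc1cccc(-n2cc3nc(-c4cccnc4C)n(C[C@H]4CCCN(CC5CCO5)C4)c(=O)c3n2)c1`, was measured in an assay on HEK293 cells for displacement of a labelled ligand from growth hormone secretagogue receptor type 1 (Homo sapiens), with a stated time of 60 min (a lower number here means a stronger inhibitor, a higher number a weaker inhibitor), and gives 23 nM. Among the measured compounds shown here, that is the lowest of the two numbers recorded so far; its only neighbour is compound 1, `COc1cccc(-n2cc3nc(-c4cccnc4C)n(C[C@H]4CCCN(CC5CCOC5)C4)c(=O)c3n2)c1`, which in this assay gives 60 nM. For the measured compounds named here, the one step between measured compounds, a 2.6-fold lower number from compound 1 to compound 2 (0.42 log units; beyond the scatter), is the replacement of oxolan-3-yl by oxetan-2-yl on a saturated chain carbon bound to an amine nitrogen in a ring.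

Compound 3, `CCO[C@H](C)CN1CCC[C@H](Cn2c(-c3cccnc3C)nc3cn(-c4cccc(OC)c4)nc3c2=O)C1`, has not yet been measured in this assay. It differs from compound 2 in one place: 1-ethoxyethyl in place of oxetan-2-yl on a saturated chain carbon bound to an amine nitrogen in a ring. The step from compound 1 to compound 2 is the only measured one that bears on this change, since it alters the same group at the same place, yet it exchanged one cyclic ether for another, whereas here a ring is opened to a chain ether. Going by the values given here, no measured pair shows what such an opening does, so the expectation rests on the group staying an ether of similar size and the step from compound 2 to compound 3 is estimated to be small, a 1.5-fold higher number from compound 2 to compound 3 (0.18 log units; within the scatter). For compound 3 the expected value in this assay is 35 nM, with a range from 12 nM to 100 nM.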

Compound 3, half-maximal inhibitory concentration: 40 nM
The estimate for compound 3 lay 1.1-fold (0.06 log units) below the measured number, within the range that was stated.
By their numbers in this assay, from the lowest: compounds 2, 3 and 1 (each within the scatter of the next, the first and the last beyond it).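

In this assay, replacing the cyclic ether with the open-chain 1-ethoxyethyl on a saturated chain carbon bound to an amine nitrogen in a ring gives a 1.7-fold higher number from compound 2 to compound 3 (0.24 log units; within the scatter) and a 1.5-fold lower number from compound 1 to compound 3 (0.18 log units; within the scatter) as its two steps, so neither step reaches beyond the scatter. Compound 1 and compound 2 had shown only that one cyclic ether could read apart from another. Compound 3 now shows that a group with no ring can stay within the scatter of both, even though those two remain apart from each other, so a ring in this group is not required for a number of this size. Nothing measured here accounts for these numbers.

What a plain butyl chain, an amine or a carboxylic acid would give on this same carbon remains open, so the compounds shown cannot tell whether an ether oxygen in this group matters at all. They also leave open what the opposite configuration of the defined stereocentre in 1-ethoxyethyl would give, and whether a longer chain ether would stay within the scatter of compound 3.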